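From benzyl to 4-methoxybenzyl on a weak compound

The source may report more compounds than this note shows. Statements on the series, on what has been measured and on what is new or still open speak of the compounds shown alone.

Compound 1 `CCSc1nnc(-c2cc(OC)c(OC)c(OC)c2)n1-c1ccc(OC)cc1` gives > 60000 nM (a limit, not a number)
Compound 2 `COc1ccc(-n2c(SCc3ccccc3)nnc2-c2cc(OC)c(OC)c(OC)c2)cc1` gives 42400 nM

For the measured compounds named here, in a functional assay on HCT-116 cells (Homo sapiens) for inhibition, read by MTT assay, with a stated time of 48 h (a lower number here means a stronger inhibitor, a higher number a weaker inhibitor), compound 2 stands at 42400 nM as the only actual number so far. Compound 1 is reported only as a limit at > 60000 nM and not as a number. Going by the values given here, the one measured step, phenyl in place of methyl on a saturated chain carbon bound to a sulfur, gave an at least 1.4-fold lower number from compound 1 to compound 2 (0.15 log units; that floor lies within the scatter) and so offers only a weak guide. On these data alone, compound 3 `COc1ccc(CSc2nnc(-c3cc(OC)c(OC)c(OC)c3)n2-c2ccc(OC)cc2)cc1` turns the benzyl of compound 2 into 4-methoxybenzyl, with methoxy in place of hydrogen on an aromatic carbon and its value is still unknown. Among the compounds with values here, no measured step tests this change, so no shift beyond the scatter is expected in this assay and no direction can be favoured. The estimate therefore stays close to compound 2 at 42400 nM and amounts to an expected 1.1-fold lower number from compound 2 to compound 3 (0.03 log units; within the scatter) overall. Compound 3 is expected at 40000 nM with an estimated range from 15000 nM to 70000 nM once measured.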

Compound 3, half-maximal inhibitory concentration: 49600 nM
For compound 3 the middle estimate is 1.2-fold (0.09 log units) below the measured one; low and high end bracket the measured number.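

Methoxy on an aromatic carbon, para to a large group, gives the first direct test of this ring in this assay: a 1.2-fold higher number from compound 2 to compound 3 (0.07 log units; within the scatter). The benzyl ring of compound 2 thus accepts 4-methoxybenzyl with no shift that can be told apart from repeat-measurement noise, so this single change gives no sign of a gain or a loss. The wider comparison, an at least 1.2-fold lower number from compound 1 to compound 3 (0.08 log units; that floor lies within the scatter), is only a floor and cannot show how large the true step is, as compound 1 is reported as a limit and not as a number: the limit of > 60000 nM in this assay, at which 1 of the 3 values shown sits.

On these data alone, whether an amine or a carboxylic acid at this same place would move the number in this assay stays open. So does the effect of a longer chain on the sulfur in place of the benzyl group.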